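Moving the Trifluoromethyl Group Around the Thioether Ring

This account rests on a few compounds, and the source may have more. Where it says the series, first, only, none or still open, it means among the compounds named here.

Of the compounds shown here, two sharing one core have been measured in a functional assay on VCaP cells (Homo sapiens) for antiproliferative activity, read by fluorescence and propidium iodide staining, with a stated time of 96 h; on this read-out lower numbers stand for stronger inhibition and higher numbers for weaker inhibition. Compound 1 `CC(O)(CSc1cc(C(F)(F)F)cc(C(F)(F)F)c1)C(=O)Nc1ccc(C#N)cc1C(F)(F)F` gives 6650 nM. Compound 2 `CC(O)(CSc1cccc(C(F)(F)F)c1)C(=O)Nc1cc(C(F)(F)F)cc(C(F)(F)F)c1` gives 9860 nM in this assay. The two numbers lie within the usual scatter of each other, so neither compound can be called the stronger of the pair, and compound 2 simply sits at the weaker-looking end of a pair that is, in effect, level.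

Compound 3 `CC(O)(CSc1ccccc1C(F)(F)F)C(=O)Nc1cc(C(F)(F)F)cc(C(F)(F)F)c1` has not yet been measured. It differs from compound 2 only on the sulfur: 2-(trifluoromethyl)phenyl in place of 3-(trifluoromethyl)phenyl on a sulfur. For the measured compounds named here, no measured pair in this small set shows what such a move of a trifluoromethyl group does, so there is no comparable step to lean on. In this assay the step is expected to stay within the scatter, with a 1.0-fold lower number from compound 2 to compound 3 (0.02 log units; within the scatter) as the estimated change. Compound 3 is therefore expected to come in near 9500 nM, somewhere between 4000 nM and 22000 nM.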

Compound 3, half-maximal inhibitory concentration: 3840 nM
Beside the measured number, compound 3's estimate is 2.5-fold (0.39 log units) above it; measured number outside the range, below it.
By their numbers in this assay, from the lowest: compounds 3, 1 and 2 (each within the scatter of the next, the first and the last beyond it).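

Where the trifluoromethyl group sits on the ring carried by the sulfur matters in this assay, with 2-(trifluoromethyl)phenyl in place of 3-(trifluoromethyl)phenyl giving a 2.6-fold lower number from compound 2 to compound 3 (0.41 log units; beyond the scatter) on the shared core. For the compounds shown here, compounds 2 and 3 hold the same atoms, joined differently, so this modest step is the first sign in the set that rearrangement alone, with no atom added or lost, can shift the number. Nothing available gives a reason for this step.

As far as these compounds go, it remains open whether a chlorine atom or a methoxy group in place of the trifluoromethyl group in 2-(trifluoromethyl)phenyl would keep the lower number of compound 3. Also open, from the compounds shown here alone, is whether the same move would give a similar step on the core of compound 1, which carries a nitrile.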